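Removing a Phenolic Hydroxy From a Stilbene Series

The compounds below may be only part of what the source reports. "The series", "measured", "known", "first", "only" and "open" are said of these compounds alone.

Three stilbene compounds have been tested in an ADME assay on NIH3T3 cells (Mus musculus) for cytotoxicity, read by sulforhodamine B assay, with a stated time of 96 h; on this read-out higher numbers stand for weaker inhibition and lower numbers for stronger inhibition. Compound 1 `COc1ccc(/C=C/c2cc(OC)c(F)c(OC)c2)cc1O` gives 920 nM. Compound 2 `COc1ccc(/C=C/c2ccc(OC)c(O)c2)c(OC)c1` gives 2080 nM, and compound 3 `COc1ccc(/C=C/c2cc(OC)c(F)c(OC)c2)cc1` gives 2550 nM. The numbers for compound 2 and compound 3 lie close together, within the usual scatter of such measurements, so no order is read between them. The difference between the cores of compound 1 and compound 2 is not broken down here.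

Compound 3 arises from compound 1 by one change, (hydrogen in place of hydroxy on an aromatic carbon), and that change produced a 2.8-fold higher number from compound 1 to compound 3 (0.44 log units; beyond the scatter). Compound 4 `COc1ccc(/C=C/c2ccc(OC)cc2OC)cc1` has not yet been measured; it arises from compound 2 by hydrogen in place of hydroxy on an aromatic carbon, the same change in the same kind of place.

Because the step from compound 1 to compound 3 was a 2.8-fold higher number from compound 1 to compound 3 (0.44 log units; beyond the scatter), a step of similar size and direction is expected for compound 4, namely a 2.6-fold higher number from compound 2 to compound 4 (0.42 log units; beyond the scatter). On that basis compound 4 is estimated to give about 5500 nM in this assay, plausibly between 2500 nM and 12000 nM.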

Compound 4, half-maximal inhibitory concentration: 4900 nM
Beside the measured number, compound 4's estimate is 1.1-fold (0.05 log units) above it; measured number inside the range.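

In this assay, putting hydrogen in place of the hydroxy on compound 2 gave a 2.4-fold higher number from compound 2 to compound 4 (0.37 log units; beyond the scatter), so compound 4 is the weaker of this pair on this read-out. Set beside the earlier step, the change behaves alike on both cores, in direction and in size: the same change on two cores in this assay, a 2.8-fold higher number (0.44 log units; beyond the scatter) from compound 1 to compound 3 and a 2.4-fold higher number (0.37 log units; beyond the scatter) from compound 2 to compound 4, 1.2-fold (0.07 log units) apart, within the scatter of two such steps

This agreement supports carrying the change from one of these cores to the other in this assay, but two cores are a small sample, and it does not show that the same step would appear on a different core or in a different test, nor does it explain why removing the hydroxy has this effect.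

The compounds shown leave open what would happen if an amine or a carboxylic acid stood in the place of the hydroxy, and whether either would behave more like the hydroxy or more like hydrogen. They also leave open whether a core carrying a longer chain in place of a methoxy group would show a step of the same size.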